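Para substituent swap on the active aryl piperazine amide

The source may hold more compounds than are shown below. What is called first, only, known or untested is meant among the compounds shown, and "the series" means these compounds.

Compound 1 `C#Cc1nc(C(=O)N2CCN(c3ccc(Cl)cc3)CC2)cs1`: 28 nM
Compound 2 `C#Cc1nc(C(=O)N2CCN(CC)CC2)cs1`: > 1000 nM (a limit, not a number)

Within the data shown here, in a functional assay on NCI-H522 cells (Homo sapiens) for cytotoxicity, with a stated time of 3 days (on this read-out lower numbers stand for stronger inhibition and higher numbers for weaker inhibition), compound 1 gives 28 nM, the only true number so far. Compound 3 `C#Cc1nc(C(=O)N2CCN(c3ccc(C(F)(F)F)cc3)CC2)cs1` carries trifluoromethyl in place of chloro on an aromatic carbon. Among the measured compounds shown here, the one measured step, an at least 35-fold higher number from compound 1 to compound 2 (1.55 log units; beyond the scatter), bears only loosely on this, as it replaces the whole aryl group on the amine nitrogen and is bounded by the limit of > 1000 nM in this assay, at which 1 of the 2 values shown sits. Compound 3 keeps that ring, so no step beyond the scatter is expected, unlike the large at least 35-fold higher number from compound 1 to compound 2 (1.55 log units; beyond the scatter). The expected step is a 1.3-fold higher number from compound 1 to compound 3 (0.10 log units; within the scatter). Compound 3 is estimated at 35 nM, within an expected range of 12 nM to 100 nM.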

Compound 3, half-maximal inhibitory concentration: 37 nM
Compound 3: middle estimate off by 1.1-fold (0.02 log units), on the low side; low and high end bracket the measured number.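

Trifluoromethyl in place of chloro on an aromatic carbon, para to a large group, brings a 1.3-fold higher number from compound 1 to compound 3 (0.12 log units; within the scatter) in this assay. This position therefore takes either group with no step beyond the scatter, although trifluoromethyl is the larger by heavy atoms and neither group carries a hydrogen-bond donor or acceptor. No measured property of either group bears on this result.

Going by these compounds, whether an amine, a carboxylic acid or a hydroxyl at this position would hold the value stays open. Also open, on these data alone, is how chloro would read on another carbon of the aromatic ring.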